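Removing a chloro group: what the measured pair suggests

This account rests on a few compounds, and the source may have more. Where it says the series, first, only, none or still open, it means among the compounds named here.

Measured so far:
compound 1 `Nc1sc2c(c1C(=O)NCc1ccccc1)CCCCCC2` — 48%
compound 2 `Nc1sc2c(c1C(=O)NCc1cccc(Cl)c1)CCCCCC2` — 49%
compound 3 `Nc1sc2c(c1C(=O)c1ccc(Cl)cc1)CCCCCC2` — 56%

Three compounds sharing one core were tested in a functional assay on CHO cells for agonist activity at adenosine receptor A1 (Homo sapiens), read by ERK phosphorylation, tested at 3 uM; a higher number here means a stronger effect of the compound at the concentration tested, a lower number a weaker effect. In this assay compound 1 gives 48% and compound 2 gives 49%. The two are related by one change, (hydrogen in place of chloro on an aromatic carbon), and the step it made is a number 1 percentage points lower from compound 2 to compound 1 (within the scatter). Compound 3 gives 56%; its value is the highest of the three, but its steps to compound 2 and to compound 1 both lie within the scatter, so no order among them can be claimed. How compound 3 and compound 2 differ is not broken down here.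

Compound 4 `Nc1sc2c(c1C(=O)c1ccccc1)CCCCCC2` has not yet been measured. It relates to compound 3 by hydrogen in place of chloro on an aromatic carbon. This is the same kind of change as that from compound 2 to compound 1, though the place differs: there the chloro sat meta to a large group, here it sits para to a large group. Because a number 1 percentage points lower from compound 2 to compound 1 (within the scatter) was within the scatter, the step from compound 3 to compound 4 is expected to be small, a number 2 percentage points lower from compound 3 to compound 4 (within the scatter). Compound 4 is therefore estimated at 54%, between 40% and 66%.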

Compound 4, a percentage reported as activity, at one concentration (the size of the read-out at that concentration, not a potency): 49%
For compound 4 the middle estimate is 5 percentage points above the measured one; low and high end bracket the measured number.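

In this assay, taking the chloro off the 4-chlorophenyl group of compound 3 gives a number 7 percentage points lower from compound 3 to compound 4 (within the scatter). Set beside the earlier pair, the same exchange of chloro for hydrogen reads alike on the two cores, though the chloro sits in a different place in each: the same change on two cores in this assay, a number 1 percentage points lower (within the scatter) from compound 2 to compound 1 and a number 7 percentage points lower (within the scatter) from compound 3 to compound 4, 6 percentage points apart, within the scatter of two such steps This shows only that, in these two pairs, the change gave no step that can be told from the scatter; it does not show that chloro is without influence in this series, nor does it show that a real effect carries from one core to another, and two pairs cannot support a rule for other cores.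

The compounds shown leave open whether another group in place of the chloro, such as methoxy or a carboxylic acid, would give a step beyond the scatter. From the compounds shown here alone, all of them also keep the same amino group on the thiophene-bearing shared core, so what an acetamide there would do also remains open.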